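The source may report more compounds than this note shows. Statements on the series, on what has been measured and on what is new or still open speak of the compounds shown alone.

Measured so far in an in vitro assay on CHO cells for displacement of a labelled ligand from Bombesin receptor subtype-3 (Homo sapiens), read by scintillation counting, with a stated time of 2 h; a higher number here means a weaker inhibitor, a lower number a stronger inhibitor:
- compound 1, `CCC(C)(C)Cc1c[nH]c(CCc2ccc(-n3cccn3)cc2)n1`: 33 nM
- compound 2, `CCC(C)(C)Cc1c[nH]c(CCc2ccc(-c3cccc(C#N)n3)cc2)n1`: 140 nM

Going by the values given here, compound 2 holds the higher of the two numbers in this assay; the only step that reaches it, a 4.2-fold higher number from compound 1 to compound 2 (0.63 log units; beyond the scatter), separates it from compound 1 by more than the usual scatter.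

Compound 3, `CCC(C)(C)Cc1c[nH]c(CCc2ccc(-c3cccc(N)n3)cc2)n1`, is not yet measured. It differs from compound 2 by amino in place of cyano on an aromatic carbon, the pyridine ring itself kept in place on the shared core.

Among the compounds with values here, the single measured step swaps the whole ring attached to the aromatic carbon and so says nothing direct about exchanging one small substituent for another on that ring. Within the data shown here, no step touches the cyano or amino group. The expectation therefore leans on compound 2 alone, and a step of about a 1.6-fold lower number from compound 2 to compound 3 (0.19 log units; within the scatter) is expected, with either direction possible. For compound 3 the estimated value in this assay is 90 nM, expected to fall between 25 nM and 320 nM.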

Compound 3, half-maximal inhibitory concentration: 7.3 nM
For compound 3 the middle estimate is 12-fold (1.09 log units) above the measured one; the measured number lies below the stated range.
By their numbers in this assay, from the lowest: compound 3; then compound 1; then compound 2.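

In this assay, a substituent exchange alone, with the ring kept, produces a larger step than the earlier ring swap: a 19-fold lower number from compound 2 to compound 3 (1.28 log units; beyond the scatter) follows from amino in place of cyano on an aromatic carbon next to the ring nitrogen. The ring comparison also depends on this substituent, since 6-cyanopyridin-2-yl in place of 1H-pyrazol-1-yl gave a higher number, whereas 6-aminopyridin-2-yl in that place gives a 4.5-fold lower number from compound 1 to compound 3 (0.66 log units; beyond the scatter) in the opposite direction. Nothing available here accounts for either step.

Open, as far as these compounds go, is whether the lower number is specific to the free amino group or also holds for a methylamino, dimethylamino or hydroxyl group at this position. Also open, from the compounds shown here alone, is how amino behaves at other positions on the same ring.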